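Thiosemicarbazide series: pyridyl swap on the amidrazone carbon

The source may hold more compounds than are shown below. What is called first, only, known or untested is meant among the compounds shown, and "the series" means these compounds.

Measured so far:
compound 1, `Cc1ccnc(/C(N)=N/NC(=S)N2CCCC2)c1`: 80%
compound 2, `N/C(=N\NC(=S)N1CCSCC1)c1ccccn1`: 80%
compound 3, `N/C(=N\NC(=S)N1CCN(c2ccccn2)CC1)c1ccc(F)cn1`: 53.1%

In a functional assay on A-375 cells (Homo sapiens) for cytotoxicity, read by MTT assay, with a stated time of 72 h, tested at 3 uM (a lower number here means less inhibition of growth, a higher number more inhibition of growth at the concentration tested), compound 1 gives 80% and compound 2 gives 80%, two values within the scatter of each other. Compound 3 stands lowest of the three numbers; in this assay compound 3 gives 53.1%, a gap beyond the scatter to both compound 1 and compound 2.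

Compound 4, `Cc1ccnc(/C(N)=N/NC(=S)N2CCN(c3ccccn3)CC2)c1`, is not yet measured. Relative to compound 3 the change is 4-methylpyridin-2-yl in place of 5-fluoropyridin-2-yl on a carbon with a double bond to nitrogen. Among the compounds with values here, no step between measured compounds isolates this change. Compound 1 carries the same 4-methylpyridin-2-yl and gives 80%, so a modest step upward in this assay is expected, possibly within the scatter. Compound 4 is estimated at 65% (range 42% to 85%). The expected step from compound 3 is a number 11.9 percentage points higher from compound 3 to compound 4 (beyond the scatter).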

Compound 4, percent growth inhibition at one concentration: 74.8%
For compound 4 the middle estimate is 9.8 percentage points below the measured one; measured number inside the range.
By their numbers in this assay, from the lowest: compound 3; then compounds 4, 1 and 2 (each within the scatter of the next).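

In this assay, 4-methylpyridin-2-yl in place of 5-fluoropyridin-2-yl on a carbon with a double bond to nitrogen gives a number 21.7 percentage points higher from compound 3 to compound 4 (beyond the scatter), so this place alone can shift growth inhibition beyond the scatter while the rest of the molecule stays fixed. The two groups match in heavy atoms, ring type and hydrogen-bond counts, so the counted features do not separate them. Nothing measured here bears on the reason for the step.

Still open, on these data alone, is whether the methyl, the loss of fluorine or the place on the ring carries the step. 4-Fluoropyridin-2-yl or 4-methoxypyridin-2-yl on the same carbon would help separate these.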